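The compounds below may be only part of what the source reports. "The series", "measured", "known", "first", "only" and "open" are said of these compounds alone.

Measured in a functional assay on AGS cells (Homo sapiens) for inhibition, read by reporter gene assay; a lower number here means a stronger inhibitor, a higher number a weaker inhibitor:
- compound 1 `Cc1ccc(OCC(=O)Nc2cccc(C(=O)O)c2)cc1`: > 30000 nM
- compound 2 `O=C(COc1ccc(Cl)cc1)Nc1cccc(C(=O)O)c1`: 10000 nM

The entry for compound 1 is a limit of the assay and not a number, as the limit of > 30000 nM in this assay, at which 1 of the 2 values shown sits, shows. Among the measured compounds shown here, compound 2 therefore holds the only true number so far, 10000 nM.

Compound 3 `O=C(COc1ccc(Br)cc1)Nc1cccc(C(=O)O)c1` has bromo in place of chloro on an aromatic carbon, para to a large group (bromo in place of chloro on an aromatic carbon). For the measured compounds named here, one measured step bears on this: an at least 3.0-fold lower number from compound 1 to compound 2 (0.47 log units; beyond the scatter), which came with chloro in place of methyl on an aromatic carbon. That was a different exchange, and one end of it is a limit, so it is only a weak guide. It does suggest that this group can matter in this assay.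

The expected change is small, a 1.7-fold lower number from compound 2 to compound 3 (0.22 log units; within the scatter), leaning towards a lower number but not beyond the scatter. For compound 3 the estimated value is 6000 nM, with an expected range of 2500 nM to 15000 nM.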

Compound 3, half-maximal inhibitory concentration: 1600 nM
Compound 3: middle estimate off by 3.8-fold (0.57 log units), on the high side; measured number outside the range, below it.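

Among the compounds shown here, the step from chloro to bromo, a 6.3-fold lower number from compound 2 to compound 3 (0.80 log units; beyond the scatter), is the first at this position with a true number at both ends. It shows that this assay can tell these two groups apart, even though one heavy atom replaces another with no change in rings, charge or hydrogen-bond donors and acceptors. Going from methyl to bromo at the same position gives an at least 18-fold lower number from compound 1 to compound 3 (1.27 log units; beyond the scatter). The entry for compound 1 is a limit and not a number, which leaves the full size of that step unknown: the limit of > 30000 nM in this assay, at which 1 of the 3 values shown sits.

From the compounds shown here alone, the order methyl, chloro, bromo rests on these three compounds alone, and what iodo, an amine or a longer chain would do at this position remains open. Going by these compounds, it is also open whether bromo would have the same effect if a nitrile stood in place of the carboxylic acid.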